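The source may report more compounds than this note shows. Statements on the series, on what has been measured and on what is new or still open speak of the compounds shown alone.

Measured compounds:
compound 1 `Cc1cc(N(C)C)nc(N[C@H]2CC[C@@H](NC(=O)c3ccc(Cl)cc3)CC2)n1` – in a functional assay on HEK293 cells for antagonist activity at melanin-concentrating hormone receptor 1 (Homo sapiens), read by FLIPR and calcium flux (a higher number here means a weaker inhibitor, a lower number a stronger inhibitor), compound 1 gives 16 nM
compound 2 `Cc1cc(N(C)C)nc(N[C@H]2CC[C@@H](NC(=O)c3ccc(F)c(F)c3)CC2)n1` – in this assay compound 2 gives 2.5 nM

Among these two numbers, compound 2 stands lowest; its nearest neighbour is compound 1, and the one measured step runs a 6.4-fold lower number from compound 1 to compound 2 (0.81 log units; beyond the scatter), a change made on the carbonyl carbon of the amide. Compound 3 `Cc1nc(N[C@H]2CC[C@@H](NC(=O)c3ccc(F)c(F)c3)CC2)nc(N(C)C)c1C` has not been measured. It differs from compound 2 in a single place: methyl in place of hydrogen on an aromatic carbon. For the measured compounds named here, this change sits on the shared core, far from the amide where the only measured step took place, so no measured step bears directly on it. The step from compound 1 to compound 2 shows that the series can move well beyond the scatter, but it says nothing about adding a methyl group to the core. Going by the values given here, with no comparable step to lean on, the expectation for compound 3 in this assay is a number close to that of compound 2, with any difference likely within the scatter, which as a step reads a 1.2-fold higher number from compound 2 to compound 3 (0.08 log units; within the scatter). Compound 3 is therefore estimated at 3 nM, in a range from 1 nM to 9 nM.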

Compound 3, half-maximal inhibitory concentration: 2.3 nM
Estimate against measurement, compound 3: 1.3-fold (0.12 log units) above, and the stated range covers the measured number.
By their numbers in this assay, from the lowest: compounds 3 and 2 (each within the scatter of the next); then compound 1.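

In this assay, methyl in place of hydrogen on the aromatic carbon ortho to a dimethylamino group and ortho to a methyl group gives a 1.1-fold lower number from compound 2 to compound 3 (0.04 log units; within the scatter), so compound 2 and compound 3 cannot be told apart. For the compounds shown here, this is the first reading from the shared core, and it contrasts with the only earlier step, on the amide side, which gave a 6.4-fold lower number from compound 1 to compound 2 (0.81 log units; beyond the scatter): at this aromatic carbon, a hydrogen and a methyl group give numbers within the scatter of each other on the 3,4-difluorophenyl amide. The data at hand offer no explanation for this result.

What the compounds shown leave open is how far this carbon can go beyond a single added carbon, since a longer chain such as ethyl, a methoxy group, a chlorine atom or an amine there could read quite differently in this assay. This single pair also leaves open whether the same methyl group would give a step within the scatter on the 4-chlorophenyl amide of compound 1.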